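A Methoxy Step Repeated on a Second Core

This account rests on a few compounds, and the source may have more. Where it says the series, first, only, none or still open, it means among the compounds named here.

Compound 1 `COc1cc2occ(-c3csc4ccccc34)c(=O)c2cc1OC` and compound 2 `COc1cc2c(=O)c(-c3csc4ccccc34)coc2c(OC)c1OC` share one core, and compound 2 carries methoxy in place of hydrogen on an aromatic carbon. In a functional assay on MDA-MB-231 cells (Homo sapiens) for antiproliferative activity, read by sulforhodamine B assay, with a stated time of 72 h (on this read-out lower numbers stand for stronger inhibition and higher numbers for weaker inhibition), compound 1 reaches only the limit > 10000 nM. Compound 2 likewise gives only the limit > 10000 nM. The step that the two limits leave unreadable from compound 1 to compound 2 cannot be sized because of the limit of > 10000 nM in this assay, at which 2 of the 3 values shown sit. Compound 3 `O=C(/C=C/c1csc2ccccc12)c1ccccc1O` stands on a different core; the difference between the two cores is not broken down here. In this assay, among the compounds with values here, compound 3 gives 5300 nM, the only number among the three. Compound 4 `COc1ccc(C(=O)/C=C/c2csc3ccccc23)c(O)c1` carries methoxy in place of hydrogen on an aromatic carbon, the same kind of change, though here the place is meta to a hydroxy group and para to a large group rather than ortho to a fused ring and to a methoxy group. The earlier step offers no guidance. Compound 4 is expected to make a step of a 1.3-fold lower number from compound 3 to compound 4 (0.12 log units; within the scatter). Compound 4 is estimated at 4000 nM, between 1500 nM and 12000 nM.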

Compound 4, half-maximal inhibitory concentration: 7400 nM
The estimate for compound 4 lay 1.9-fold (0.27 log units) below the measured number; low and high end bracket the measured number.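

In this assay the methoxy change on the second core makes a 1.4-fold higher number from compound 3 to compound 4 (0.14 log units; within the scatter), so on this core the change moves the number no further than the usual scatter. On the core of compound 1 the same change cannot be read, because both values there are limits: the limit of > 10000 nM in this assay, at which 2 of the 4 values shown sit. The result therefore does not show whether the change carries from one core to the other, only that it made no readable difference at this one place on the second core.

The compounds shown leave open how the second core responds to an amine or a carboxylic acid at that place. They also leave open whether a methoxy group elsewhere on that ring would give a step beyond the scatter.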